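A few compounds are considered here, and "the series" means these few. Any claim that something is new, unique, unknown or untested is made for them only; others in the source may bear on it.

Measured so far:
compound 1 `CC(c1ccc(-c2ccccc2)c(F)c1)c1nnc2n1N=C(c1ccc(Cl)cc1)CS2` — 8700 nM
compound 2 `COc1ccc2cc(C(C)c3nnc4n3N=C(c3ccc(C(F)(F)F)cc3)CS4)ccc2c1` — 6900 nM
compound 3 `CC(c1ccc(-c2ccccc2)c(F)c1)c1nnc2n1N=C(c1ccccc1)CS2` — 7400 nM

The three compounds share one core and differ only at the two aryl groups. In a functional assay on MCF7 cells (Homo sapiens) for inhibition, read by sulforhodamine B assay, with a stated time of 72 h (a lower number here means a stronger inhibitor, a higher number a weaker inhibitor), compound 2 gives the lowest of the three numbers, yet compound 3 stands within the scatter of it, and compound 1 is also within the scatter; nothing separates the three compounds on the numbers shown.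

Within the data shown here, the single step between compounds that differ in one place, a 1.2-fold lower number from compound 1 to compound 3 (0.07 log units; within the scatter), concerns hydrogen in place of chloro on an aromatic carbon of the same aryl ring and moves nothing beyond the scatter.

Compound 4 `COc1ccc(C2=Nn3c(nnc3C(C)c3ccc4cc(OC)ccc4c3)SC2)cc1` is not yet measured. It differs from compound 2 by methoxy in place of trifluoromethyl on an aromatic carbon. Among the measured compounds shown here, no measured pair shows this exchange; the only comparable step, from compound 1 to compound 3, replaces a halogen on the same ring with hydrogen and is within the scatter, and compounds 1, 2 and 3 together span a narrow band. On that basis a step within the scatter is expected, direction undetermined, so that a 1.0-fold higher number from compound 2 to compound 4 (0.01 log units; within the scatter) is the estimate for compound 4. Compound 4 is expected to give about 7000 nM in this assay, with a range from 3000 nM to 16000 nM.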

Compound 4, half-maximal inhibitory concentration: 6600 nM
Beside the measured number, compound 4's estimate is 1.1-fold (0.03 log units) above it; the range from low to high includes it.
By their numbers in this assay, from the lowest: compounds 4, 2, 3 and 1 (each within the scatter of the next).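

In this assay, among these compounds, the exchange on the aromatic carbon para to a large group gives a 1.0-fold lower number from compound 2 to compound 4 (0.02 log units; within the scatter), the first direct reading of methoxy in place of trifluoromethyl at this position. A group of 4 heavy atoms and 0 hydrogen-bond acceptors gives way here to one of 2 heavy atoms and 1 hydrogen-bond acceptor, and the step stays within the scatter, as does a 1.2-fold lower number from compound 1 to compound 3 (0.07 log units; within the scatter), so neither listed change on this ring separates its pair of compounds. No measurement among the data bears on the cause of this result.

Open, going by these compounds, is whether any group at this position can move the number beyond the scatter, for example an amine, a carboxylic acid or a longer chain such as butoxy. Among the compounds shown here, also open is whether methoxy in place of trifluoromethyl reads the same when the other aryl group is that of compound 1 rather than that of compound 2, since the single pair for this exchange carries only the latter.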